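Extending the amide chain of compound 1 with an allylamino group

This account rests on a few compounds, and the source may have more. Where it says the series, first, only, none or still open, it means among the compounds named here.

Compound 1 `CCCC(=O)Nc1ccc(C2=NNC(=O)CC2)cc1` is the anchor of this small set. Among the compounds with values here, in a functional assay for inhibition, with Homo sapiens as the target (a lower number here means that less compound is needed, a higher number that more compound is needed for the effect), compound 1 gives 1.44 ug/mL, the only actual number recorded so far. Within the data shown here, its companion compound 2 `CC(=O)Nc1ccc(C2=NN(C)C(=O)CC2)cc1` differs from it in more than one place, so no single step connects the two. In this assay compound 2 gives > 46.4 ug/mL, which is a limit of the assay rather than a number. Compound 2 therefore sits at the limit of > 46.4 ug/mL in this assay, at which 1 of the 2 values shown sits.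

The next compound, compound 3 `C=CCNCC(=O)Nc1ccc(C2=NNC(=O)CC2)cc1`, is made from compound 1 by one change: allylamino in place of ethyl on a saturated chain carbon bound to a carbonyl carbon. The chain hanging off the amide keeps its length in carbons but gains a nitrogen that can both donate and accept a hydrogen bond, and a terminal double bond.

Among the measured compounds shown here, with no measured step of this kind to lean on, the expectation for this assay is a modest shift toward a higher number, of a size that may or may not exceed the scatter, worded as a 2.1-fold higher number from compound 1 to compound 3 (0.32 log units; beyond the scatter). Compound 3 is estimated to give 3 ug/mL, with a plausible range from 0.7 ug/mL to 15 ug/mL.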

Compound 3, half-maximal effective concentration: about 21.5 ug/mL
Estimate against measurement, compound 3: 7.2-fold (0.86 log units) below; measured number above the stated range.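

In this assay, the saturated chain carbon bound to a carbonyl carbon turns out to be a sensitive place on compound 1: putting allylamino in place of ethyl there gives a 15-fold higher number from compound 1 to compound 3 (1.17 log units; beyond the scatter), a large step and the first in this set that changes one place only. It shows that more compound is needed for the effect once this group enters, even though the core of compound 1 stays untouched, so the end of the amide chain matters to the read-out and does not merely go along for the ride. The step still ends at a real reading, whereas compound 2 alone sits at a limit of the assay, which is not a number: the limit of > 46.4 ug/mL in this assay, at which 1 of the 3 values shown sits.

The allylamino group brings its nitrogen, its hydrogen-bond donor and acceptor, and its double bond all at once, so the compounds shown cannot tell which of these goes with the step. A saturated propylamino group, a plain longer alkyl chain or a carboxylic acid at this same place would begin to pull those features apart.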